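A few compounds are considered here, and "the series" means these few. Any claim that something is new, unique, unknown or untested is made for them only; others in the source may bear on it.

Three measured compounds share one core and differ only in the aryl group on the carbon with a double bond to nitrogen. Compound 1 is `O=C(CSc1nnc(-c2ccncc2)o1)N/N=C/c1ccc(F)cc1`, compound 2 is `COc1ccc(/C=N/NC(=O)CSc2nnc(-c3ccncc3)o2)cc1`, and compound 3 is `O=C(CSc1nnc(-c2ccncc2)o1)N/N=C/c1ccccc1O`. In a functional assay on HepG2 cells (Homo sapiens) for cytotoxicity, read by MTT assay, with a stated time of 48 h (on this read-out higher numbers stand for weaker inhibition and lower numbers for stronger inhibition), compound 1 gives 12300 nM. Compound 2 gives 15800 nM, and compound 3 gives 3510 nM. The step of a 1.3-fold higher number from compound 1 to compound 2 (0.11 log units; within the scatter) leaves compound 1 and compound 2 indistinguishable, whereas a 3.5-fold lower number from compound 1 to compound 3 (0.54 log units; beyond the scatter) and a 4.5-fold lower number from compound 2 to compound 3 (0.65 log units; beyond the scatter) set compound 3 apart from both. Compound 1 therefore stands with the second highest of the three numbers, close to compound 2 and well away from compound 3.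

Compound 4 is `O=C(CSc1nnc(-c2ccncc2)o1)N/N=C/c1cc(Cl)ccc1O`. Relative to compound 1 the change is 5-chloro-2-hydroxyphenyl in place of 4-fluorophenyl on a carbon with a double bond to nitrogen. Within the data shown here, the steps that bear on this are the two that bring in a 2-hydroxyphenyl group, a 3.5-fold lower number from compound 1 to compound 3 (0.54 log units; beyond the scatter) and a 4.5-fold lower number from compound 2 to compound 3 (0.65 log units; beyond the scatter), both modest and both in the same direction; compound 4 carries that same 2-hydroxyphenyl group with a chlorine added, and nothing among the measured compounds shows what that chlorine does. The expectation is a step of roughly the size seen for compound 3, a 3.8-fold lower number from compound 1 to compound 4 (0.58 log units; beyond the scatter). Compound 4 is thus estimated at 3200 nM, within a range from 1300 nM to 8500 nM.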

Compound 4, half-maximal inhibitory concentration: 3970 nM
Beside the measured number, compound 4's estimate is 1.2-fold (0.09 log units) below it, within the range that was stated.
By their numbers in this assay, from the lowest: compounds 3 and 4 (each within the scatter of the next); then compounds 1 and 2 (each within the scatter of the next).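

In this assay, the chlorine that turns the 2-hydroxyphenyl group into 5-chloro-2-hydroxyphenyl makes no difference that can be read, with a 1.1-fold higher number from compound 3 to compound 4 (0.05 log units; within the scatter). The separation from the groups without a hydroxy group survives that addition, with a 3.1-fold lower number from compound 1 to compound 4 (0.49 log units; beyond the scatter) and a 4.0-fold lower number from compound 2 to compound 4 (0.60 log units; beyond the scatter), both modest and beyond the scatter. On the carbon with a double bond to nitrogen, the four compounds thus fall into two pairs, compounds 3 and 4 on the lower side and compounds 1 and 2 on the higher, with no compound going against this split, and no measurement at hand explains it.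

The compounds shown leave open whether the step belongs to the hydroxy group itself or to its place on the ring, a question that a 4-hydroxyphenyl group or a 2-methoxyphenyl group on the same carbon would address. Also open, from the compounds shown here alone, is whether other additions to the 2-hydroxyphenyl group, such as an amine or a carboxylic acid, would leave the number as undisturbed as the chlorine does.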